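Compound 3: a second carboxy side group on the core

A few compounds are considered here, and "the series" means these few. Any claim that something is new, unique, unknown or untested is made for them only; others in the source may bear on it.

Measured so far:
- compound 1 `COc1ccc(/C=C\c2cc(OC)c(OC)c(OC)c2)cc1OCc1ccc(C=O)cc1` gives 900 nM here
- compound 2 `COc1ccc(/C=C\c2cc(OC)c(OC)c(OC)c2)cc1OCc1ccc(CN2CCCC[C@H]2C(=O)O)cc1` gives > 10000 nM here, a limit

In a functional assay on MC-38 cells (Mus musculus) for antiproliferative activity, read by CCK-8 assay, with a stated time of 48 h (a lower number here means a stronger inhibitor, a higher number a weaker inhibitor), compound 2 stands at > 10000 nM, which is a limit and not a number. Compound 3 `COc1ccc(/C=C\c2cc(OC)c(OC)c(OC)c2)cc1OCc1ccc(CN[C@H](C(=O)O)[C@H](C)O)cc1` carries (1-carboxy-2-hydroxypropyl)amino in place of 2-carboxypiperidin-1-yl on a saturated chain carbon bound to an aromatic carbon. Within the data shown here, only one measured step bears on this change, namely an at least 11-fold higher number from compound 1 to compound 2 (1.04 log units; beyond the scatter), and it is large. Among the measured compounds shown here, that step replaces formyl with (2-carboxypiperidin-1-yl)methyl, and no measured step swaps one carboxy-bearing group for another. Compound 3 also keeps a carboxy-bearing group on the same carbon, so the loss seen in an at least 11-fold higher number from compound 1 to compound 2 (1.04 log units; beyond the scatter) is expected to persist. In this assay the estimated step is a step that the limit leaves unreadable from compound 2 to compound 3, and nothing beyond the scatter is expected, in either direction. The estimate for compound 3 is 12000 nM, with an expected range from 4000 nM to 40000 nM, and a report as a limit is the likelier outcome.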

Compound 3, half-maximal inhibitory concentration: > 10000 nM
Compound 3 gave a limit, no number; the forecaster's own chance of this, stated with the estimate: 70%; the middle value lies beyond the limit too.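

In this assay, ((1-carboxy-2-hydroxypropyl)amino)methyl in place of formyl on an aromatic carbon gives an at least 11-fold higher number from compound 1 to compound 3 (1.04 log units; beyond the scatter), so a second carboxy-bearing side group, this one with no ring, also falls far short of the aldehyde. Compound 3 stands at > 10000 nM, which is a limit and not a number. The six-membered ring of 2-carboxypiperidin-1-yl is thus not required for the loss, while the step between the two carboxy-bearing side groups cannot be read and no order between them can be stated: the limit of > 10000 nM in this assay, at which 2 of the 3 values shown sit.

Open is whether the loss follows the carboxylic acid, the amine nitrogen or the two together, as both side groups shown carry both. A methyl ester in place of the carboxylic acid, or a morpholine on the same saturated chain carbon, would pull these apart and might bring a side group back to a readable number in this assay.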